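The compounds below may be only part of what the source reports. "The series", "measured", "known", "first", "only" and "open" are said of these compounds alone.

Measured so far:
compound 1, `N#C/C(=C\c1c(F)c(F)c(F)c(F)c1F)C(=O)c1ccc[nH]1`: > 100000 nM
compound 2, `COc1ccc(CNC(=O)/C(C#N)=C/c2ccco2)cc1`: 31000 nM

In a functional assay on SW480 cells (Homo sapiens) for inhibition, read by MTT assay, with a stated time of 72 h (a lower number here means a stronger inhibitor of growth, a higher number a weaker inhibitor of growth), compound 2 gives 31000 nM. Among the measured compounds shown here, compound 1 returns no number at all in this assay; its entry, > 100000 nM, is a limit of the assay, and the series so far sits at the limit of > 100000 nM in this assay, at which 1 of the 2 values shown sits, for that one entry. For the measured compounds named here, compound 2 thus stands alone as the only compound with a number in this assay; the other entry is a limit. Going by the values given here, the two measured compounds differ from one another in more than one place, so no single step between them can be drawn; their two values show only that compound 2 lies inside the measurable range of this assay while compound 1 does not.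

Compound 3, `COc1ccc(CNC(=O)/C(C#N)=C/c2ccc(Br)o2)cc1`, differs from compound 2 by bromo in place of hydrogen on an aromatic carbon. Among the compounds with values here, no step of this kind has been measured, so the size can only be expected, not read off. The change expected from this substitution is a modest one toward stronger growth inhibition, a 2.1-fold lower number from compound 2 to compound 3 (0.32 log units; beyond the scatter), not far beyond the usual scatter. For compound 3 the expected value in this assay is 15000 nM, with a range from 5000 nM to 60000 nM.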

Compound 3, concentration for 50% growth inhibition: 14000 nM
The estimate for compound 3 lay 1.1-fold (0.03 log units) above the measured number, and the stated range covers the measured number.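

In this assay, among the compounds shown here, bromo in place of hydrogen on the five-membered aromatic ring with 1 oxygen, next to the ring oxygen, gives a 2.2-fold lower number from compound 2 to compound 3 (0.35 log units; beyond the scatter) and is the first change that can be read as a single step. For the compounds shown here, the earlier compounds showed only that compound 2 lies inside the measurable range; this step shows that the number at this carbon responds to substitution, moving modestly toward stronger growth inhibition on going from furan-2-yl to 5-bromofuran-2-yl. No measured property among the data shown bears on this step, which therefore stands as an observation without an explanation.

Whether this shift is specific to bromo remains open, as chloro, methyl and an amine at the same carbon are not among the compounds shown. Also open, from the compounds shown here alone, is whether a step of similar size would appear with the bromo kept and the methoxy group replaced by a carboxylic acid or a longer chain.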